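Compound 2 as sole anchor for compound 3

This account rests on a few compounds, and the source may have more. Where it says the series, first, only, none or still open, it means among the compounds named here.

- compound 1 `CC(C)(O)c1ccc(-c2cnc3c(n2)N(CC2CCCCC2)CC(=O)N3)cn1` gives "not determined" (no result reported)
- compound 2 `CO[C@H]1CC[C@H](CN2CC(=O)Nc3ncc(-c4ccc(C(C)(C)O)nc4)nc32)CC1` gives 2980 ng.h/mL

The read-out for this series is an ADME assay on the whole organism for pharmacokinetics, with Rattus norvegicus as the target, at a dose of 5 mg/kg by the oral route; on this read-out higher numbers stand for higher exposure at the dose given and lower numbers for lower exposure. For the measured compounds named here, compound 2 holds the only number, so it cannot yet be ranked against any other compound, and no exposure trend can be drawn. Going by the values given here, compound 1 offers no comparison, and no step between measured compounds is available to calibrate the next one.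

Compound 3 `CO[C@H]1CC[C@H](N2CC(=O)Nc3ncc(-c4ccc(C(C)(C)O)nc4)nc32)CC1` is still to be measured in this assay. The change from compound 2 is 4-methoxycyclohexyl in place of (4-methoxycyclohexyl)methyl on a nitrogen on an aromatic ring in a ring. The shared core and the remaining substituent stay the same, and the 4-methoxycyclohexyl keeps its two defined stereocentres.

Among the compounds with values here, with no measured precedent for this change, the size of the step remains uncertain, and a result within the usual scatter would not be surprising. A modest upward movement is nevertheless expected, and a 1.8-fold higher number from compound 2 to compound 3 (0.27 log units; within the scatter) is the estimated step, anchored only on compound 2 at 2980 ng.h/mL. For compound 3 the expected value is 5500 ng.h/mL, with an estimated range of 2000 ng.h/mL to 14000 ng.h/mL.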

Compound 3, area under the concentration-time curve: 35800 ng.h/mL
For compound 3 the middle estimate is 6.5-fold (0.81 log units) below the measured one; the whole stated range lies below it.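

In this assay, for the compounds shown here, 4-methoxycyclohexyl in place of (4-methoxycyclohexyl)methyl on a nitrogen on an aromatic ring in a ring gives a 12-fold higher number from compound 2 to compound 3 (1.08 log units; beyond the scatter) and is the first readable step. It shows that exposure at the dose given is sensitive to this position: the two groups keep the same six-membered non-aromatic ring of carbon only, the same hydrogen-bond counts and two defined stereocentres, and differ in size only as 9 heavy atoms against 8, yet the step lies well beyond the scatter. No measurement is available that bears on the origin of this step, so it stands as an observation from a single pair of compounds.

As far as these compounds go, compound 1 gives "not determined" (no result reported), so the steps involving it cannot be read and the contribution of the methoxy group to exposure remains unknown. Also open, from the compounds shown here alone, is whether the higher exposure of compound 3 would survive a longer chain carrying the same ring, or an amine or a carboxylic acid in place of the methoxy group.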